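Swapping the ester alcohol of a phosphonate prodrug

The compounds below may be only part of what the source reports. "The series", "measured", "known", "first", "only" and "open" are said of these compounds alone.

Measured so far:
compound 1 `CC(C)(C)C(=O)OCO[P@@]1(=O)OCC(C)(C)[C@H](C(=O)NCCC(=O)OCCS(C)(=O)=O)O1` gives < 0.16 h in an ADME assay on blood (Homo sapiens) for pharmacokinetics; on this read-out higher numbers stand for a longer-lived compound and lower numbers for a shorter-lived compound
compound 2 `COC(=O)CCNC(=O)[C@@H]1O[P@@](=O)(OCOC(=O)c2cc(C)nn2C)OCC1(C)C` gives > 1 h in this assay

Neither of these two numbers is a true measurement. Compound 1 sits at the limit of < 0.16 h in this assay, at which 1 of the 2 values shown sits, so its half-life is shorter than the assay can report. Compound 2 sits at the limit of > 1 h in this assay, at which 1 of the 2 values shown sits, so its half-life is longer than the assay can report. Going by the values given here, the two compounds differ in several places at once, so no single structural step between measured compounds is available, and the size of any one change cannot be read off these data.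

Compound 3 `CC(C)(C)C(=O)OCO[P@@]1(=O)OCC(C)(C)[C@H](C(=O)NCCC(=O)OC2CCN(Cc3ccccc3)C2)O1` is the next compound and differs from compound 1 in one place: 1-benzylpyrrolidin-3-yl in place of 2-(methylsulfonyl)ethyl on an oxygen next to a carbonyl group. Since nothing measured tells how this change acts, the expectation rests only on where compound 1 stands. The step from compound 1 to compound 3 in this assay is expected to be an at least 1.8-fold higher number from compound 1 to compound 3 (0.27 log units; that floor lies within the scatter), upward and modest, with a fair chance of no change beyond the scatter. Compound 3 is estimated at 0.3 h, in the range 0.1 h to 1.5 h, and it may again be reported only as a limit.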

Compound 3, half-life: 0.19 h
The estimate for compound 3 lay 1.6-fold (0.20 log units) above the measured number; low and high end bracket the measured number.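

In this assay compound 3 gives 0.19 h, a true number and not a limit, so this oxygen can carry a larger group, with a five-membered ring and a benzene ring, and still give a half-life the assay can report. Compound 1 remains a limit: the limit of < 0.16 h in this assay, at which 1 of the 3 values shown sits.

Putting 1-benzylpyrrolidin-3-yl in place of 2-(methylsulfonyl)ethyl on an oxygen next to a carbonyl group gives an at least 1.1-fold higher number from compound 1 to compound 3 (0.07 log units; that floor lies within the scatter), which is only a floor: the true step could be larger, but nothing here shows a change beyond the scatter.

From the compounds shown here alone, whether a carboxylic acid or a longer open alkyl chain at this place, with the rest of compound 1 kept, would move the half-life beyond the scatter stays open, as does the question of which part of 1-benzylpyrrolidin-3-yl counts for the reading. Compound 2, at > 1 h, is also a limit and differs from compound 1 in several places at once, so the data do not tell which of its changes goes with that reading.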